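Amide to sulfonamide exchange on the aryl cap of compound 1

The source may hold more compounds than are shown below. What is called first, only, known or untested is meant among the compounds shown, and "the series" means these compounds.

Measured so far:
compound 1, `N#CN/C(=N\CCNC(=O)c1ccc(N=[N+]=[N-])cc1)NCCCOc1cccc(CN2CCCCC2)c1`: 7.9 in a functional assay on cardiac atrium for antagonist activity at histamine H2 receptor (Cavia porcellus); on this read-out lower numbers stand for lower potency and higher numbers for higher potency (the scale is a negative logarithm)
compound 2, `N#CN/C(=N\CCNC(=O)c1ccccc1)NCCCCOc1cccc(CN2CCCCC2)c1`: 7.67 in this assay
compound 3, `N#CN/C(=N\CCCNC(=O)c1ccccc1)NCCCCOc1cccc(CN2CCCCC2)c1`: 6.6 in this assay

Compound 1 holds the highest number of the three, but compound 2 sits within the scatter of it; only compound 3 lies clearly lower. Within the data shown here, the single measured step between one-change neighbours, a number 1.07 log units lower from compound 2 to compound 3 (beyond the scatter), concerns benzamidomethyl in place of benzamido on the chain and leaves the aryl cap untouched. Compound 4, `Cc1ccc(S(=O)(=O)NCC/N=C(\NC#N)NCCCOc2cccc(CN3CCCCC3)c2)cc1`, differs from compound 1 by (4-methylphenyl)sulfonyl in place of (4-azidophenyl)carbonyl on an amine nitrogen. Among the measured compounds shown here, no measured step bears on a carbonyl-to-sulfonyl exchange, so the series offers no direct guide. A small downward step, a number 0.40 log units lower from compound 1 to compound 4 (beyond the scatter), is expected, with wide uncertainty. Compound 4 is estimated at 7.5, range 6.8 to 8.2.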

Compound 4, negative logarithm of the antagonist equilibrium constant: 6.13
Compound 4: the middle estimate sits 1.37 log units above what was measured; the whole stated range lies above it.
By their numbers in this assay, from the lowest: compound 4; then compound 3; then compounds 2 and 1 (each within the scatter of the next).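

Among these compounds, exchanging (4-azidophenyl)carbonyl for (4-methylphenyl)sulfonyl on this amine nitrogen gives a number 1.77 log units lower from compound 1 to compound 4 (beyond the scatter) in this assay and is the first measured sign that this cap position is not indifferent to change. The step joins two changes, carbonyl to sulfonyl and azido to methyl on the ring, and these compounds cannot separate them. Nothing measured here accounts for the loss.

Open, on these data alone, is which of the two changes carries the step. A (4-methylphenyl)carbonyl cap on the same amine nitrogen would separate them.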